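A few compounds are considered here, and "the series" means these few. Any claim that something is new, unique, unknown or untested is made for them only; others in the source may bear on it.

Among the compounds with values here, in a functional assay on PC-3 cells (Homo sapiens) for inhibition, read by MTT assay, with a stated time of 72 h (a lower number here means a stronger inhibitor, a higher number a weaker inhibitor), compound 2 `C=CC(=O)Nc1cccc(NC(=O)CSc2nc(Nc3ccccc3C)c3ccccc3n2)c1` gives 23200 nM, which is the highest of the two numbers so far; its nearest neighbour is compound 1 `C=CC(=O)Nc1cccc(NC(=O)CSc2nc(Nc3ccccc3Br)c3ccccc3n2)c1`, which in this assay gives 17100 nM. Within the data shown here, the single step connecting these two, a 1.4-fold higher number from compound 1 to compound 2 (0.13 log units; within the scatter), lies within the scatter of repeated measurements.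

Compound 3 `C=CC(=O)Nc1cccc(NC(=O)CSc2nc(Nc3cccc(Cl)c3)c3ccccc3n2)c1` has not yet been measured in this assay. It differs from compound 2 by one change: 3-chlorophenyl in place of 2-methylphenyl on a nitrogen on an aromatic ring.

Among the measured compounds shown here, only one measured step offers any guidance, and it concerns the same ring that is altered here: the exchange from compound 1 to compound 2 swapped one substituent for another on that ring and produced a difference within the scatter. The present change again exchanges a methyl-bearing ring for a halogen-bearing ring, and on that basis no step beyond the scatter is expected in this assay; the estimated step is a 1.2-fold lower number from compound 2 to compound 3 (0.06 log units; within the scatter).

For compound 3 the expected value in this assay is therefore 20000 nM, with a range from 8000 nM to 50000 nM.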

Compound 3, half-maximal inhibitory concentration: 12300 nM
For compound 3 the middle estimate is 1.6-fold (0.21 log units) above the measured one; the measured number falls inside the stated range.
By their numbers in this assay, from the lowest: compounds 3, 1 and 2 (each within the scatter of the next).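

In this assay, 3-chlorophenyl on this nitrogen in place of 2-methylphenyl gives a 1.9-fold lower number from compound 2 to compound 3 (0.28 log units; within the scatter), and in place of 2-bromophenyl it gives a 1.4-fold lower number from compound 1 to compound 3 (0.14 log units; within the scatter). The earlier pair showed only that methyl and bromo could be exchanged within one named group, 2-substituted phenyl, without a step beyond the scatter; these new steps extend that reading to a group whose substituent has both a different name and a different number, so the three aryl groups on this nitrogen cannot be told apart in this assay. Nothing available explains this outcome or links it to any property of the groups.

Going by these compounds, all three compounds carry a phenyl ring with a single methyl, bromo or chloro substituent on this nitrogen, so it remains open whether plain phenyl, an aminophenyl, a carboxyphenyl or a saturated cyclohexyl group would give a step beyond the scatter. The acrylamide and the thioacetamide chain are also the same throughout, so the shown compounds say nothing about how a saturated propanamide in place of the acrylamide would read in this assay.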